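Aryl amine swap on the shared core: compound 4

The compounds below may be only part of what the source reports. "The series", "measured", "known", "first", "only" and "open" are said of these compounds alone.

Compound 1 `O=C1C(Nc2cccc(Cl)c2)=CC(=O)c2c1nc1n2[C@H]2OC[C@@H](O)[C@H]2OC1` gives 1530 nM in a functional assay on MGC-803 cells (Homo sapiens) for inhibition, read by sulforhodamine B assay (on this read-out higher numbers stand for weaker inhibition and lower numbers for stronger inhibition), the lowest of the two numbers shown; compound 2 `O=C1C=C(Nc2ccc(C(F)(F)F)cc2)C(=O)c2c1nc1n2[C@H]2OC[C@@H](O)[C@H]2OC1` gives 2820 nM, within the scatter of compound 1. Compound 3 `O=C1C=C(NC2CCCC2)C(=O)c2c1nc1n2[C@H]2OC[C@@H](O)[C@H]2OC1` reaches only > 8000 nM, which is a limit of the assay and not a number. Among the compounds with values here, the single measured step, an at least 2.8-fold higher number from compound 2 to compound 3 (0.45 log units; beyond the scatter), replaces an aromatic ring on the amine nitrogen with a saturated one and weakens inhibition, its size being only a lower bound because compound 3 sits at the limit of > 8000 nM in this assay, at which 1 of the 3 values shown sits. Compound 4 `CCc1ccc(NC2=CC(=O)c3c(nc4n3[C@H]3OC[C@@H](O)[C@H]3OC4)C2=O)cc1` differs from compound 1 by 4-ethylphenyl in place of 3-chlorophenyl on an amine nitrogen. Within the data shown here, this aryl-to-aryl exchange has no measured counterpart: the step from compound 2 to compound 3 does not bear on it, since compound 1 and compound 4 both keep a phenyl ring on the amine nitrogen, and the only aryl-to-aryl comparison available, compound 1 against compound 2, shows two values within the scatter of each other. For compound 4 the step is therefore expected to stay within the scatter, a 1.3-fold higher number from compound 1 to compound 4 (0.12 log units; within the scatter). The estimate for compound 4 in this assay is 2000 nM, with a range from 800 nM to 5000 nM.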

Compound 4, half-maximal inhibitory concentration: 1110 nM
Compound 4: the middle estimate sits 1.8-fold (0.26 log units) above what was measured; the measured number falls inside the stated range.
By their numbers in this assay, from the lowest: compounds 4, 1 and 2 (each within the scatter of the next, the first and the last beyond it). At a limit, above all of these: compound 3.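

In this assay, the exchange of 3-chlorophenyl for 4-ethylphenyl on the amine nitrogen gives a 1.4-fold lower number from compound 1 to compound 4 (0.14 log units; within the scatter), so at this position the chlorine is not needed to hold the number at this level. The aryl groups are not all interchangeable, however: compound 4 at 1110 nM and compound 2 at 2820 nM lie beyond the scatter of each other, while compound 1 lies within the scatter of both. Nothing given here accounts for the new step.

Since the group and its place on the ring change together from compound 1 to compound 4, 4-chlorophenyl and 3-ethylphenyl would be needed to separate the two. On these data alone, it also remains open whether a phenyl ring carrying a carboxylic acid or a dimethylamino group stays in this range.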